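Swapping Piperidine for Methylpiperazine on a Weak Inhibitor

The source may hold more compounds than are shown below. What is called first, only, known or untested is meant among the compounds shown, and "the series" means these compounds.

For the measured compounds named here, compound 2 `C=CC(=O)Nc1cc(N)nc(Sc2c(OCC)nc(N3CCCCC3)nc2OCC)n1` is one of two compounds measured in a functional assay on SK-BR-3 cells (Homo sapiens) for activation, read by Western blot; a higher number here means a weaker inhibitor, a lower number a stronger inhibitor. In this assay compound 2 gives 10000 nM, the larger of the two numbers recorded so far, though only by a margin that falls within the usual scatter. The other, compound 1 `C=CC(=O)Nc1ccnc(Sc2c(C)nc(N3CCN(C)CC3)nc2C)n1`, gives in this assay 5000 nM; the two values therefore cannot be told apart with confidence. Compound 3 `C=CC(=O)Nc1cc(N)nc(Sc2c(OCC)nc(N3CCN(C)CC3)nc2OCC)n1` has not yet been measured. It differs from compound 2 in one place: 4-methylpiperazin-1-yl in place of piperidin-1-yl on an aromatic carbon. Compound 1 also carries a 4-methylpiperazin-1-yl group, but the rest of its structure differs from compound 2 in several places, so its value says nothing about this single change on its own. Going by the values given here, with no measured step for this change, no shift beyond the scatter is expected, a 1.4-fold lower number from compound 2 to compound 3 (0.15 log units; within the scatter). Compound 3 is therefore estimated at 7000 nM, with a likely range from 2000 nM to 25000 nM.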

Compound 3, half-maximal inhibitory concentration: 1500 nM
The estimate for compound 3 lay 4.7-fold (0.67 log units) above the measured number; the measured number lies below the stated range.
By their numbers in this assay, from the lowest: compound 3; then compounds 1 and 2 (each within the scatter of the next).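

In this assay, putting 4-methylpiperazin-1-yl in place of piperidin-1-yl gives a 6.7-fold lower number from compound 2 to compound 3 (0.82 log units; beyond the scatter), a stronger inhibitor on a shared core. This shows that the group on this aromatic carbon, between two ring nitrogen atoms, can change the reading by more than the usual scatter. The two earlier compounds differ from each other in several places, so they could not isolate this change. No measurement available here bears on the reason for the step.

The compounds shown leave open whether the second ring nitrogen or its methyl group accounts for the step, a question that an unsubstituted piperazine or a morpholine at this position could help to separate. From the compounds shown here alone, it also remains open whether the same swap would give a similar step on the core of compound 1.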